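The source may report more compounds than this note shows. Statements on the series, on what has been measured and on what is new or still open speak of the compounds shown alone.

Measured compounds in this series:

compound 1 `Cc1ccc(CNC(=O)CC2c3ccccc3N=C(N3CCN(CCN(C)C)CC3)N2c2ccc(-c3ccccc3)cc2)cc1` — 2330 nM
compound 2 `CN(C)CCN1CCN(C2=Nc3ccccc3C(CC(=O)NCc3ccc(F)cc3)N2c2ccc(-c3ccccc3)cc2)CC1` — 3090 nM
compound 3 `COc1ccc(CNC(=O)CC2c3ccccc3N=C(N3CCN(CCN(C)C)CC3)N2c2ccc(-c3ccccc3)cc2)cc1` — 2470 nM

All three share one core and differ only in the group carried on the aromatic ring of the benzyl amide. In a functional assay on SK-OV-3 cells (Homo sapiens) for cytotoxicity, read by MTT assay, with a stated time of 48 h (a lower number here means a stronger inhibitor, a higher number a weaker inhibitor), compound 3 stands second highest of the three numbers; the nearest of the others is reached by a 1.1-fold higher number from compound 1 to compound 3 (0.03 log units; within the scatter) and the furthest by a 1.3-fold lower number from compound 2 to compound 3 (0.10 log units; within the scatter), so no separation among the three is resolved.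

Compound 4 `CN(C)CCN1CCN(C2=Nc3ccccc3C(CC(=O)NCc3ccccn3)N2c2ccc(-c3ccccc3)cc2)CC1` is not yet measured. The change from compound 3 is pyridin-2-yl in place of 4-methoxyphenyl on a saturated chain carbon bound to an amide-type nitrogen. The measured steps that bear on it are all swaps of one substituent on that aromatic ring: a 1.3-fold higher number from compound 1 to compound 2 (0.12 log units; within the scatter), a 1.1-fold higher number from compound 1 to compound 3 (0.03 log units; within the scatter) and a 1.3-fold lower number from compound 2 to compound 3 (0.10 log units; within the scatter), each within the scatter. Among the measured compounds shown here, the present change is of a different kind, since the ring itself is exchanged for one with a hetero atom and the methoxy is lost, and no measured pair covers such an exchange. With every observed variation at this position flat, the expectation is a change no larger than the scatter: a 1.1-fold higher number from compound 3 to compound 4 (0.02 log units; within the scatter). Compound 4 is therefore estimated at 2600 nM, with a range of 1200 nM to 5600 nM.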

Compound 4, half-maximal inhibitory concentration: 5080 nM
Compound 4: the middle estimate sits 2.0-fold (0.29 log units) below what was measured; measured number inside the range.
By their numbers in this assay, from the lowest: compounds 1, 3, 2 and 4 (each within the scatter of the next, the first and the last beyond it).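

In this assay, among the compounds shown here, the exchange of the substituted phenyl ring for pyridin-2-yl gives the first steps at this position that pass the scatter, with a 2.1-fold higher number from compound 3 to compound 4 (0.31 log units; beyond the scatter) and a 2.2-fold higher number from compound 1 to compound 4 (0.34 log units; beyond the scatter) both modest, whereas a 1.6-fold higher number from compound 2 to compound 4 (0.22 log units; within the scatter) stays within it, so compound 2 goes against any clean separation of compound 4 from the three earlier compounds. The position that looked flat to swaps of one substituent on the ring is therefore not shown to be equally flat to an exchange of the ring itself, although this rests on compound 4 alone and the shift is small. No data on hand account for the shift.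

The change in compound 4 alters the ring and removes the substituent in one move, so the compounds shown leave open which of the two carries the step, and a plain benzyl group on the amide nitrogen would help separate them. Also open, on these data alone, are the pyridin-3-yl and pyridin-4-yl isomers, an amine or carboxylic acid on the ring, and a longer chain between the amide nitrogen and the ring.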